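The source may report more compounds than this note shows. Statements on the series, on what has been measured and on what is new or still open speak of the compounds shown alone.

Compound 1 `Cc1cc2c(c(N)nn2C)c(=O)[nH]1`: in an assay on isolated protein for inhibition of RAC-beta serine/threonine-protein kinase (Homo sapiens), read by mobility shift assay, tested at 30 uM (a higher number here means more inhibition at the concentration tested (going by the name of the read-out), a lower number less inhibition), compound 1 gives 4%.
Compound 2 `Cn1nc(N)c2c(=O)[nH]c(-c3ccccc3)cc21`: in this assay compound 2 gives 4%.
Compound 3 `COCCNc1nc(C)cc2c1c(N)nn2C`: in this assay compound 3 gives -3%.

Of the compounds shown here, three have been measured so far, and none of them shows much inhibition in this assay. Compound 1 and compound 2 differ in one place, (phenyl in place of methyl on an aromatic carbon), and the step of no change at the digits printed from compound 1 to compound 2 (within the scatter). Compound 3 stands on a different core; the difference between the two cores is not broken down here. Its value in this assay sits within the scatter of both compound 1 and compound 2, so the three numbers cannot be ordered.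

Compound 4 `COCCNc1nc(-c2ccccc2)cc2c1c(N)nn2C` has not yet been measured in this assay. It arises from compound 3 by phenyl in place of methyl on an aromatic carbon. Among the compounds with values here, this is the same kind of change as the one from compound 1 to compound 2, though the surroundings are not identical: in the earlier pair the site is meta to a group of 1 heavy atom, whereas in compound 3 it is meta to a (2-methoxyethyl)amino group (5 heavy atoms).

Because the earlier step of no change at the digits printed from compound 1 to compound 2 (within the scatter), compound 4 is expected to stay close to compound 3, with an estimated step of a number 3 percentage points higher from compound 3 to compound 4 (within the scatter). The estimate for compound 4 in this assay is therefore 0%, most likely between -12% and 12%.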

Compound 4, a percentage reported as inhibition, at one concentration (the size of the read-out at that concentration, not a potency): -1%
Beside the measured number, compound 4's estimate is 1 percentage points above it; the measured number falls inside the stated range.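

On the second core, phenyl in place of methyl gives a number 2 percentage points higher from compound 3 to compound 4 (within the scatter), and set beside the earlier step in this assay, the change behaves alike on both cores: the same change on two cores in this assay, no change at the digits printed (within the scatter) from compound 1 to compound 2 and a number 2 percentage points higher (within the scatter) from compound 3 to compound 4, 2 percentage points apart, within the scatter of two such steps. What carries over, then, is only the absence of a readable effect: on neither core does the larger aromatic group move the number beyond the scatter, whether the neighbouring group is the carbonyl and amide hydrogen of the core of compound 1 or the (2-methoxyethyl)amino group of compound 3. This does not show that the change would act the same way on a compound with real inhibition, since all four compounds sit close to the floor of this assay, where two flat steps agree almost by default and say little about how a substituent at this carbon contributes.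

The compounds shown leave open whether anything on these cores gives a clear signal in this assay, and so whether a step of this kind could ever be seen to transfer. An amine or a carboxylic acid in place of the phenyl, or a longer chain in place of the (2-methoxyethyl)amino group, lies outside what these four numbers can address.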